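Methoxy in place of trifluoromethyl: notes on half-life

A few compounds are considered here, and "the series" means these few. Any claim that something is new, unique, unknown or untested is made for them only; others in the source may bear on it.

- compound 1 `CN1CCC(Oc2ccc(N3C(=S)N(c4cnc(C#N)c(C(F)(F)F)c4)C(=O)C34CCC4)cc2)CC1` gives 1.55 h
- compound 2 `N#Cc1ncc(N2C(=O)C3(CCC3)N(c3ccc(CN4CCNCC4)cc3)C2=S)cc1C(F)(F)F` gives > 3 h (a limit of the assay)
- compound 3 `COc1cc(N2C(=O)C3(CCC3)N(c3ccc(OC4CCN(C)CC4)cc3)C2=S)cnc1C#N` is not yet measured

The read-out for all three is an ADME assay on microsomes from liver (Mus musculus, strain CD1) for metabolic stability; on this read-out higher numbers stand for a longer-lived compound and lower numbers for a shorter-lived compound. Among the compounds with values here, compound 1 holds the only actual number in this short series, so it has no measured number to be ranked against. Compound 2 gives > 3 h, which is a limit of the assay.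

Compound 3 differs from compound 1 in one place: methoxy in place of trifluoromethyl on an aromatic carbon. In words, methoxy stands in place of trifluoromethyl on an aromatic carbon, ortho to a cyano group. Within the data shown here, the one measured step is an at least 1.9-fold higher number from compound 1 to compound 2 (0.28 log units; that floor lies within the scatter). Its floor lies within the scatter, and it concerns the (1-methylpiperidin-4-yl)oxy group, not the trifluoromethyl group. Among the measured compounds shown here, no measured step covers the present change, so the data give no direction, and no step beyond the scatter is expected in this assay. The expected step is a 1.1-fold lower number from compound 1 to compound 3 (0.04 log units; within the scatter). For compound 3 the estimated half-life is 1.4 h, with an expected range of 0.7 h to 2.8 h.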

Compound 3, half-life: 1.9 h
Estimate against measurement, compound 3: 1.4-fold (0.13 log units) below; the measured number falls inside the stated range.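

In this assay, methoxy in place of trifluoromethyl, on the aromatic carbon ortho to a cyano group, gives a 1.2-fold higher number from compound 1 to compound 3 (0.09 log units; within the scatter). Within the data shown here, this is the first measured step at this position, and it shows that compound 1 and compound 3 cannot be told apart on this read-out, even though the group goes from 4 heavy atoms with three fluorine to 2 heavy atoms with one oxygen, and the entering group carries a hydrogen-bond acceptor that the leaving group lacks. Unlike the step to compound 2, which gives only a floor, this step joins two actual numbers, so its size can be read directly rather than being cut off by the one ceiling seen in this series: the limit of > 3 h in this assay, at which 1 of the 3 values shown sits.

The compounds shown leave open whether other groups at this position, such as a chlorine atom, an ethoxy group or a dimethylamino group, would also stay within the scatter, as one replacement gives only one step. They also leave open whether methoxy gives the same result when the (piperazin-1-yl)methyl group of compound 2 stands in place of the (1-methylpiperidin-4-yl)oxy group.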